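Varying the Ether Substituent on a TRPV1 Antagonist Scaffold

The source may report more compounds than this note shows. Statements on the series, on what has been measured and on what is new or still open speak of the compounds shown alone.

Compound 1 `CC(C(=O)NCc1ccc(C(F)(F)F)cc1N1CCCC1)c1ccc(NS(C)(=O)=O)c(F)c1`: 2.3 nM
Compound 2 `COc1ccc(N2CCN(c3cc(C(F)(F)F)ccc3CNC(=O)C(C)c3ccc(NS(C)(=O)=O)c(F)c3)CC2)cc1`: 1.6 nM
Compound 3 `CC(C)COc1cc(C(F)(F)F)ccc1CNC(=O)C(C)c1ccc(NS(C)(=O)=O)c(F)c1`: 0.8 nM

In an assay on CHO cells for antagonist activity at transient receptor potential cation channel subfamily V member 1 (Homo sapiens), read by FLIPR (a higher number here means a weaker inhibitor, a lower number a stronger inhibitor), compound 3 gives the lowest number of the three. Compound 2 sits nearest to it, within the scatter, so no order between them can be read; compound 1 stands further off, with a 2.9-fold lower number from compound 1 to compound 3 (0.46 log units; beyond the scatter), a modest step beyond the scatter.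

Compound 4 `CC(C(=O)NCc1ccc(C(F)(F)F)cc1SCc1ccccc1)c1ccc(NS(C)(=O)=O)c(F)c1` differs from compound 3 in one place: benzylsulfanyl in place of isobutoxy on an aromatic carbon. Among the compounds with values here, the only measured step touching this position is that from compound 1 to compound 3, which swaps pyrrolidin-1-yl for isobutoxy. Within the data shown here, no measured pair exchanges an alkoxy for a thioether, so the step in this assay is expected to be small, likely within the scatter. Compound 4 is therefore estimated at 1.5 nM, with a range from 0.5 nM to 5 nM, a step of a 1.9-fold higher number from compound 3 to compound 4 (0.27 log units; within the scatter).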

Compound 4, inhibition constant: 0.5 nM
Beside the measured number, compound 4's estimate is 3.0-fold (0.48 log units) above it; low and high end bracket the measured number.
By their numbers in this assay, from the lowest: compounds 4, 3, 2 and 1 (each within the scatter of the next, the first and the last beyond it).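

In this assay, the position on the aromatic carbon ortho to a large group accepts benzylsulfanyl as well as isobutoxy, with a 1.6-fold lower number from compound 3 to compound 4 (0.20 log units; within the scatter) and so no order between the two. Benzylsulfanyl also stands clear of pyrrolidin-1-yl, with a 4.6-fold lower number from compound 1 to compound 4 (0.66 log units; beyond the scatter), so compound 3 and compound 4 both lie beyond the scatter from compound 1. No available evidence explains these steps.

As far as these compounds go, what a benzyloxy or an isobutylsulfanyl group would give at this position remains open, and so does whether the sulfur or the aromatic ring matters more. From the compounds shown here alone, the effect of a primary amine there is also open.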